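Working notes: from compound 2 to compound 4

This account rests on a few compounds, and the source may have more. Where it says the series, first, only, none or still open, it means among the compounds named here.

- compound 1 `CCc1ccc(Nc2nccs2)cc1OCC=C(C)C` gives 31000 nM
- compound 2 `N#Cc1ccc(Nc2nccs2)cc1OCc1ccco1` gives 18000 nM
- compound 3 `Clc1ccc(Nc2nccs2)cc1OCc1ccsc1` gives 38000 nM

All three values come from a functional assay on MT2 cells (Homo sapiens) for cytotoxicity, read by MTT assay (on this read-out higher numbers stand for lower toxicity in this test and lower numbers for higher toxicity in this test), and span a narrow range. Compound 2 stands at the low end of the three numbers with 18000 nM as its value. That value lies within the scatter of compound 1, while compound 3 gives a higher number that lies just beyond the scatter.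

The next compound is compound 4 `N#Cc1ccc(Nc2nccs2)cc1OCc1nccs1`, which carries 1,3-thiazol-2-yl in place of furan-2-yl on a saturated chain carbon bound to an oxygen on an aromatic ring. Among the measured compounds shown here, no two measured compounds differ in one place only, so no measured step speaks directly to this change. The expectation rests only on the narrow spread of the series, whose ends are compound 2 at 18000 nM and compound 3 at 38000 nM in the same test. The expected change in this assay is a 1.4-fold higher number from compound 2 to compound 4 (0.14 log units; within the scatter) and so no step beyond the scatter is expected, with only a slight lean toward a higher number. For compound 4 the estimated value is 25000 nM with an expected range from 10000 nM to 60000 nM in this test.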

Compound 4, half-maximal cytotoxic concentration: 20000 nM
For compound 4 the middle estimate is 1.3-fold (0.10 log units) above the measured one; the measured number falls inside the stated range.
By their numbers in this assay, from the lowest: compounds 2, 4, 1 and 3 (each within the scatter of the next, the first and the last beyond it).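

In this assay, among the compounds shown here, the only one-place comparison reads a 1.1-fold higher number from compound 2 to compound 4 (0.05 log units; within the scatter), so at this place, on a saturated chain carbon bound to an oxygen on an aromatic ring, the read-out does not separate 1,3-thiazol-2-yl from furan-2-yl. With the nitrile and the rest of the core held constant, going from a ring with 1 hetero atom to one with 2, and from 1 hydrogen-bond acceptor to 2, leaves this pair without a change that can be read. Nothing available explains why the number holds across this exchange.

As far as these compounds go, it stays open whether the same exchange would read the same way with the chlorine of compound 3 or the ethyl group of compound 1 in place of the nitrile, since those two compounds also differ from compound 2 in the group on the ether oxygen. The compounds shown also leave open how a group of another kind at this place, such as an amine or a carboxylic acid in place of the five-membered aromatic ring, would read in this assay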